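The source may report more compounds than this note shows. Statements on the series, on what has been measured and on what is new or still open speak of the compounds shown alone.

Working notes on the series, read in an ADME assay on MT4 cells (Homo sapiens) for cytotoxicity; on this read-out lower numbers stand for higher toxicity in this test and higher numbers for lower toxicity in this test. Compound 1 `O=C(NC(=S)Nc1cccc(C(F)(F)F)c1)c1ccccc1` gives > 100000 nM, which is a limit. Compound 3 `CC(=O)NC(=S)Nc1cccc(C(F)(F)F)c1` gives > 100000 nM, again a limit. This places compound 3 at the limit of > 100000 nM in this assay, at which 2 of the 3 values shown sit. Compound 2 `FC(F)(F)c1cccc(NC(=S)Nc2ccc(I)cc2)c1` gives a measured 10000 nM.

Compound 4 `FC(F)(F)c1cccc(NC(=S)NCc2ccco2)c1` differs from compound 3 as follows: (furan-2-yl)methyl in place of acetyl on an amide-type nitrogen. That is (furan-2-yl)methyl in place of acetyl on an amide-type nitrogen.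

Two measured steps are available. Going by the values given here, the first is a step that the two limits leave unreadable from compound 1 to compound 3, which offers no size to carry over. The second is an at least 10-fold higher number from compound 2 to compound 3 (1.00 log units; beyond the scatter), and it changes the same amide-type nitrogen, so it is the one that bears on this change. Compound 4 regains a ring on that nitrogen, as compound 2 does at 10000 nM. Some fall from the limit is therefore expected, probably smaller than that step.

The expected change is an at least 2.5-fold lower number from compound 3 to compound 4 (0.39 log units; beyond the scatter), toward a lower number in this assay, and a reading at the limit remains possible. For compound 4 the estimated value is 40000 nM, with an expected range of 12000 nM to 100000 nM.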

Compound 4, half-maximal cytotoxic concentration: 43000 nM
Estimate against measurement, compound 4: 1.1-fold (0.03 log units) below; the measured number falls inside the stated range.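

In this assay, placing (furan-2-yl)methyl on the amide-type nitrogen gives an at least 2.3-fold lower number from compound 3 to compound 4 (0.36 log units; beyond the scatter), and the same group in place of 4-iodophenyl gives a 4.3-fold higher number from compound 2 to compound 4 (0.63 log units; beyond the scatter). Going by these compounds alone, a ring on this nitrogen therefore does not by itself fix the reading at the level of compound 2: the two ring-bearing groups differ beyond the scatter, and compound 4 is the first of the series to give a measured value that lies apart from both compound 2 and the limit. Compound 3 stands at a limit, so the step to compound 4 gives only a bound on the size of the change: the limit of > 100000 nM in this assay, at which 2 of the 4 values shown sit.

Open, on these data alone, is whether the distance between compound 2 and compound 4 follows from the kind of ring or from the carbon that links it to the nitrogen. A benzyl group, a plain butyl chain or a chain ending in an amine on the same nitrogen would bear on that question.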